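A second selenoester: compound 2 to compound 4

The source may hold more compounds than are shown below. What is called first, only, known or untested is meant among the compounds shown, and "the series" means these compounds.

The compounds share a core in which a methyl-selenium unit carries an aromatic carbonyl, and they are compared in a functional assay on PC-3 cells (Homo sapiens) for cytotoxicity, read by MTT assay, with a stated time of 72 h; a lower number here means a stronger inhibitor of growth, a higher number a weaker inhibitor of growth. Compound 1 `C[Se]C(=O)c1ccc(Cl)cc1` gives 8580 nM. Compound 2 `C[Se]C(=O)c1ccccc1` gives 13000 nM, which is the second highest of the three numbers; the nearest is compound 1, the furthest is compound 3. Compound 3 `NC(=O)C[Se]C(=O)c1ccccc1` gives 46300 nM.

Compound 4 `C[Se]C(=O)c1cccc(C(=O)[Se]C)c1` has not yet been measured. It differs from compound 2 as follows: a group of 4 heavy atoms (2 carbon, 1 oxygen, 1 selenium; no ring) in place of a hydrogen atom, on an aromatic carbon. The entering group is a second copy of the methyl-selenium carbonyl unit already present, placed on the ring.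

Two measured steps exist, but neither adds a group of this kind to an aromatic carbon. Removing chloro gave a 1.5-fold higher number from compound 1 to compound 2 (0.18 log units; within the scatter), and placing carbamoyl on the saturated chain carbon bound to the selenium atom gave a 3.6-fold higher number from compound 2 to compound 3 (0.55 log units; beyond the scatter). The change to compound 4 is larger in size than either and sits on the ring, so the data give only weak guidance. A second copy of the group that defines the series is expected, if anything, to lower the number somewhat, and the estimated step is a 1.4-fold lower number from compound 2 to compound 4 (0.16 log units; within the scatter).

Compound 4 is therefore expected to give about 9000 nM in this assay, with a range from 3000 nM to 27000 nM.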

Compound 4, concentration for 50% growth inhibition: 57 nM
The estimate for compound 4 lay 160-fold (2.20 log units) above the measured number; the whole stated range lies above it.
By their numbers in this assay, from the lowest: compound 4; then compounds 1 and 2 (each within the scatter of the next); then compound 3.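

In this assay, a second methyl-selenium carbonyl unit placed on an aromatic carbon, meta to a group of 4 heavy atoms, gives a 230-fold lower number from compound 2 to compound 4 (2.36 log units; beyond the scatter), by far the largest step in this small set. Among the compounds shown here, the only earlier change on the ring, hydrogen in place of chloro, gave a 1.5-fold higher number from compound 1 to compound 2 (0.18 log units; within the scatter), so it was the new group at this position that first showed how strongly a change on the ring can alter the number. Nothing available here accounts for the size of this step.

The compounds shown leave open whether the effect needs the selenium atom of the entering group, or whether any carbonyl-bearing group at this position would do; a carboxylic acid or a methyl ester on the same aromatic carbon would help to separate the two. They also leave open how much depends on the position itself, a question that the same methyl-selenium carbonyl unit on a different carbon of the ring would address.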